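Nitro on the furan: from compound 2 to compound 3

This account rests on a few compounds, and the source may have more. Where it says the series, first, only, none or still open, it means among the compounds named here.

The series holds compound 1 `COc1ccc2[nH]c(C)c(Cc3nn4c(Cc5ccc(OC)c(OC)c5)nnc4s3)c2c1`, compound 2 `COc1ccc(Cl)c(-c2nnc3n2NC(c2ccco2)S3)c1` and the not yet measured compound 3 `COc1ccc(Cl)c(-c2nnc3n2NC(c2ccc([N+](=O)[O-])o2)S3)c1`. In a functional assay on the whole organism (strain Wistar Albino) for inhibition, with Rattus norvegicus as the target, read by paw edema, with a stated time of 2 h, at a dose of 20 mg/kg (on this read-out lower numbers stand for less inhibition and higher numbers for more inhibition at the one dose given (going by the name of the read-out)), compound 1 gives 16.2%. In this assay compound 2 gives 18.7%, and the two numbers lie within the usual scatter of each other, so compound 2 stands level with compound 1 rather than apart from it. Compound 3 differs from compound 2 by nitro in place of hydrogen on an aromatic carbon. Within the data shown here, no step between measured compounds is at hand to gauge such a change, so the step in this assay is expected to be small, a number 3.3 percentage points higher from compound 2 to compound 3 (within the scatter), not beyond the scatter. In this assay compound 3 is estimated at 22%, within a range from 10% to 36%.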

Compound 3, a percentage reported as inhibition, in the whole organism at one dose (the size of the read-out at that dose, not a potency): 18.5%
Compound 3: middle estimate off by 3.5 percentage points, on the high side; the measured number falls inside the stated range.
By their numbers in this assay, from the lowest: compounds 1, 3 and 2 (each within the scatter of the next).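

In this assay, nitro in place of hydrogen on the aromatic carbon next to the ring oxygen gives a number 0.2 percentage points lower from compound 2 to compound 3 (within the scatter), so furan-2-yl and 5-nitrofuran-2-yl stand level at this dose and time. Among these compounds, this is the first step that can be read, and it is a single one for this position. No other measurement bears on this result. On these data alone, whether an amine or a carboxylic acid at the same carbon would give a step beyond the scatter stays open. As far as these compounds go, whether nitro would give a similar step on another ring also stays open.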